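A few compounds are considered here, and "the series" means these few. Any claim that something is new, unique, unknown or untested is made for them only; others in the source may bear on it.

Measured compounds:
compound 1, `CCCCCCCCCCn1cc(COC[C@@H]2OC[C@H](N)[C@@H]2O)nn1`, 9640 nM
compound 2, `CCCCCCCCCCCCn1cc(COC[C@@H]2OC[C@H](N)[C@@H]2O)nn1`, 2210 nM
compound 3, `CCCCCCCCCCCCCCCCn1cc(COC[C@@H]2OC[C@H](N)[C@H]2O)nn1`, 2260 nM

Within the data shown here, in a functional assay on MCF7 cells (Homo sapiens) for antiproliferative activity, read by MTT assay, with a stated time of 48 h (a higher number here means a weaker inhibitor, a lower number a stronger inhibitor), the one counted step is a 4.4-fold lower number from compound 1 to compound 2 (0.64 log units; beyond the scatter), a change of ethyl in place of hydrogen on a saturated chain carbon, ten or more bonds along the chain from an aromatic nitrogen. Compound 3 shares the same kind of change with compound 4, but the difference between the core of compound 1 and the core of compound 3 is not broken down here; the values of compound 2 and compound 3 lie within the scatter of each other, while compound 1 stands apart from compound 3 with a higher number.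

Compound 4, `CCCCCCCCCCCCCCCCCCn1cc(COC[C@@H]2OC[C@H](N)[C@H]2O)nn1`, carries the same change as compound 1 to compound 2: ethyl in place of hydrogen on a saturated chain carbon, ten or more bonds along the chain from an aromatic nitrogen. The step from compound 2 to compound 3 brought no further gain, so the expected step of a 1.1-fold lower number from compound 3 to compound 4 (0.03 log units; within the scatter) is small. Compound 4 is estimated at 2100 nM, within 900 nM to 5000 nM.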

Compound 4, half-maximal inhibitory concentration: 1930 nM
Beside the measured number, compound 4's estimate is 1.1-fold (0.04 log units) above it; the measured number falls inside the stated range.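

In this assay, ethyl in place of hydrogen on a saturated chain carbon, ten or more bonds along the chain from an aromatic nitrogen, gives a 1.2-fold lower number from compound 3 to compound 4 (0.07 log units; within the scatter) on the core of compound 3. The size of this step therefore does not carry over from one core to the other:
the same change on two cores in this assay, a 4.4-fold lower number (0.64 log units; beyond the scatter) from compound 1 to compound 2 and a 1.2-fold lower number (0.07 log units; within the scatter) from compound 3 to compound 4, 3.7-fold (0.57 log units) apart, beyond the scatter of two such steps
Among these compounds, each core contributes only one pair, and the two pairs also start from different chain lengths, so the data do not separate a core effect from a chain-length effect and give no general rule for this change.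

Still open, as far as these compounds go, is how a longer chain than that of compound 4 would read on the core of compound 3. Also open, from the compounds shown here alone, is whether an amine or a carboxylic acid at the chain end would alter the number in this assay.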